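Oxindole series, cyclooctyl replacing fluorophenyl at quaternary carbon

A few compounds are considered here, and "the series" means these few. Any claim that something is new, unique, unknown or untested is made for them only; others in the source may bear on it.

Measured so far:
compound 1 `O=C1Nc2c(ccc(F)c2F)C1(c1ccc(O)cc1)c1ccc(F)cc1` — 2.6 nM
compound 2 `COc1ccc(C2(c3cccc(O)c3)C(=O)Nc3c2ccc(F)c3F)cc1` — 196 nM

Two compounds of the shared core have numbers in a functional assay on MCF7 cells (Homo sapiens) for cytotoxicity, read by WST assay, with a stated time of 72 h; on this read-out higher numbers stand for weaker inhibition and lower numbers for stronger inhibition. Compound 1 gives 2.6 nM, the lowest of the two. Among the compounds with values here, compound 2 gives 196 nM, a gap beyond the scatter; compound 2 differs from compound 1 in more than one place, so its gap cannot be traced to a single change and no step is available between measured compounds.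

Compound 3 `O=C1Nc2c(ccc(F)c2F)C1(c1ccc(O)cc1)C1CCCCCCC1` is not yet measured. It differs from compound 1 by one change: cyclooctyl in place of 4-fluorophenyl on a saturated ring carbon. An aromatic ring is exchanged for a saturated ring of larger size at the same quaternary position.

Within the data shown here, no measured step of this kind exists, and the only other number, that of compound 2, involves a different pair of changes. An expectation must rest on compound 1 alone. The change is expected to cost potency, with a step of a 12-fold higher number from compound 1 to compound 3 (1.06 log units; beyond the scatter) beyond the scatter; the estimate for compound 3 is 30 nM, within the range 5 nM to 300 nM. The uncertainty is wide.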

Compound 3, half-maximal inhibitory concentration: > 1000 nM
Compound 3 ended at the assay's limit; the forecaster's own chance of this, stated with the estimate: 5%; middle value at least 33-fold (1.52 log units) away from the limit.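

In this assay, within the data shown here, exchanging 4-fluorophenyl for cyclooctyl on this saturated ring carbon gives an at least 380-fold higher number from compound 1 to compound 3 (2.58 log units; beyond the scatter), the first step that can be traced to a single change, and it shows that potency at this position does not survive this exchange even though the 4-hydroxyphenyl and the rest of the core of compound 1 stay in place. Compound 3 gives > 1000 nM, which is a limit of the assay and not a number. The step is therefore a minimum, and how far the loss truly extends cannot be read from this result: the limit of > 1000 nM in this assay, at which 1 of the 3 values shown sits.

The single change alters the aromatic character and the size of the ring together, so the compounds shown do not tell which of the two carries the loss; cyclohexyl, a saturated six-membered carbon ring, would separate them. Also open, on these data alone, is what the fluorine contributes to the value of compound 1, and whether a plain phenyl or a small open chain such as isopropyl at the same carbon keeps any of the potency.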